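Trifluoromethyl for chloro on the urea aryl of compound 1

The source may report more compounds than this note shows. Statements on the series, on what has been measured and on what is new or still open speak of the compounds shown alone.

The series shares one core, seen in compound 1 `O=C(Nc1cccc(-n2cc(-c3ccncc3)c(-c3ccc(Cl)c(O)c3)n2)c1)Nc1ccc(Cl)c(Cl)c1`, compound 2 `O=C(Nc1cccc(-n2cc(-c3ccncc3)c(-c3ccc(Cl)c(O)c3)n2)c1)Nc1cc(C(F)(F)F)cc(C(F)(F)F)c1` and compound 3 `COc1cc(-c2nn(-c3cccc(NC(=O)Nc4cccc(C(F)(F)F)c4)c3)cc2-c2ccncc2)ccc1Cl`; the compounds differ in the aryl group on the far side of the urea and in the substituent on the chlorophenyl ring. In a functional assay on SNB-19 cells (Homo sapiens) for inhibition, read by sulforhodamine B assay, with a stated time of 48 h (a higher number here means a weaker inhibitor of growth, a lower number a stronger inhibitor of growth), compound 1 gives only a limit, > 32500 nM, so no number is known for it. This is the point noted by the limit of > 32500 nM in this assay, at which 1 of the 3 values shown sits. In this assay compound 2 gives 8960 nM, and compound 3 gives 4000 nM; these two values lie within the usual scatter of each other, so no order between them is claimed.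

The step under study goes from compound 1 to compound 4 `O=C(Nc1cccc(-n2cc(-c3ccncc3)c(-c3ccc(Cl)c(O)c3)n2)c1)Nc1ccc(Cl)c(C(F)(F)F)c1`, not yet measured in this assay. The change is trifluoromethyl in place of chloro on an aromatic carbon; read one bond further out it is 3,4-dichlorophenyl to 4-chloro-3-(trifluoromethyl)phenyl. Within the data shown here, no step between two measured compounds is available to size it.

The expectation rests on compound 2, which gives 8960 nM, and on compound 3, which gives 4000 nM, both carrying trifluoromethyl on that ring. Compound 1, without it, gives only a limit in this assay, > 32500 nM. Compound 4 is therefore expected to move toward stronger inhibition of growth, by an at least 3.2-fold lower number from compound 1 to compound 4 (0.51 log units; beyond the scatter), a step expected to exceed the scatter. Compound 4 is estimated at 10000 nM, within a range of 3500 nM to 32500 nM.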

Compound 4, concentration for total growth inhibition: 4860 nM
The estimate for compound 4 lay 2.1-fold (0.31 log units) above the measured number, and the stated range covers the measured number.
By their numbers in this assay, from the lowest: compounds 3, 4 and 2 (each within the scatter of the next, the first and the last beyond it). At a limit, above all of these: compound 1.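

In this assay the series now has a step that changes one place only, trifluoromethyl in place of chloro on an aromatic carbon, ortho to a chloro group and meta to a large group: an at least 6.6-fold lower number from compound 1 to compound 4 (0.82 log units; beyond the scatter). Among these compounds, compound 2 and compound 3 also carry trifluoromethyl on this aryl ring, but each differs from compound 1 in more than one place, so compound 4 is the first to tie a gain in growth inhibition to this single change, with the other chloro group and the rest of the core of compound 1 kept. The value of compound 1, > 32500 nM, is a limit and not a number, and the step gives only a lower bound on the size of the change because of it: the limit of > 32500 nM in this assay, at which 1 of the 4 values shown sits.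

Going by these compounds, the true size of the step remains open, as does whether it would hold with the methoxy of compound 3 in place of the hydroxy on the chlorophenyl ring. The compounds shown also leave open whether trifluoromethyl is specifically required at this carbon, or whether a nitrile, a methyl group or an amine there would serve as well.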